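A few compounds are considered here, and "the series" means these few. Any claim that something is new, unique, unknown or untested is made for them only; others in the source may bear on it.

Working notes on the series. In an ADME assay on HEK293 cells (Homo sapiens) for cytotoxicity, read by MTT assay, with a stated time of 48 h (a lower number here means a stronger inhibitor, a higher number a weaker inhibitor), compound 1 `CCS(=O)(=O)Nc1ccc(NC(=O)c2ccc(Cl)cc2)cc1OC` gives only a limit, > 250000 nM. Compound 2 `CCS(=O)(=O)Nc1ccc(NC(=O)c2ccc(Cl)c([N+](=O)[O-])c2)cc1OC` gives 63700 nM in this assay, a step of an at least 3.9-fold lower number from compound 1 to compound 2 (0.59 log units; beyond the scatter). Compound 3 `COc1cc(NC(=O)c2ccc(Cl)cc2)ccc1NS(=O)(=O)C(F)(F)F` again returns a limit in this assay, > 250000 nM. The step that the two limits leave unreadable from compound 1 to compound 3 cannot be sized; the limit of > 250000 nM in this assay, at which 2 of the 3 values shown sit, is where compound 1 and compound 3 both stand. Among the compounds with values here, compound 4 `CCS(=O)(=O)Nc1ccc(NC(=O)c2ccc(Cl)cc2)cc1F` differs from compound 1 by fluoro in place of methoxy on an aromatic carbon, a change matched by none of the measured steps, and the nitro step concerns a different part of the structure, so no direction is taken from it. Compound 4 is therefore expected to stay near the limit of this assay, estimated at 200000 nM (range 50000 nM to 250000 nM), the expected step being an at least 1.2-fold lower number from compound 1 to compound 4 (0.09 log units; that floor lies within the scatter).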

Compound 4, half-maximal inhibitory concentration: 53400 nM
Estimate against measurement, compound 4: 3.7-fold (0.57 log units) above; measured number inside the range.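

Fluoro in place of methoxy, ortho to a (ethylsulfonyl)amino group, gives an at least 4.6-fold lower number from compound 1 to compound 4 (0.67 log units; beyond the scatter) in this assay. Within the data shown here, this position therefore also moves the number beyond the scatter, which the earlier compounds, changed only at the nitro site and on the sulfonyl sulfur, did not show. Compound 1 stands at a limit, so the true size of this step cannot be read: the limit of > 250000 nM in this assay, at which 2 of the 4 values shown sit.

From the compounds shown here alone, whether chloro or an amine at this position would move the number the same way stays open. Also open, going by these compounds, is whether the same change gives a comparable step with trifluoromethyl on the sulfonyl sulfur.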